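Replacing tert-butyl with methoxy on a shared core

A few compounds are considered here, and "the series" means these few. Any claim that something is new, unique, unknown or untested is made for them only; others in the source may bear on it.

The account follows two compounds built on the same core. Going by the values given here, compound 1 `CC(C)(C)c1ccc(OCCCON2C(N)=NC(N)=NC23CCSCC3)cc1` was tested in a functional assay on MDA-MB-231 cells (Homo sapiens) for antiproliferative activity, read by MTT assay, with a stated time of 72 h (on this read-out higher numbers stand for weaker inhibition and lower numbers for stronger inhibition), where compound 1 gives 1 nM, the only number reported among the compounds here. Compound 2 `NC1=NC2(CCOCC2)N(OCCCOc2ccc(F)cc2)C(N)=N1` belongs to the same series, but in this assay compound 2 gives "not determined" (no result reported), so no number stands beside it and it offers no comparison.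

Compound 3 `COc1ccc(OCCCON2C(N)=NC(N)=NC23CCSCC3)cc1` differs from compound 1 in one place: methoxy in place of tert-butyl on an aromatic carbon. Among the compounds with values here, no pair of measured compounds shows what such a change does here, so the direction of the step rests on the structural change alone. The writer expects a modest loss of activity for compound 3, a step of a 5.0-fold higher number from compound 1 to compound 3 (0.70 log units; beyond the scatter) that may or may not exceed the scatter. In this assay, compound 3 is estimated at 5 nM, with a range from 1 nM to 30 nM.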

Compound 3, half-maximal inhibitory concentration: 350 nM
Compound 3: middle estimate off by 70-fold (1.85 log units), on the low side; measured number outside the range, above it.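

In this assay, going by these compounds alone, the replacement of tert-butyl by methoxy on the aromatic carbon gives a 350-fold higher number from compound 1 to compound 3 (2.54 log units; beyond the scatter) and so supplies the first measured step. The earlier compounds shown here gave a single number and no comparison, whereas this pair shows that activity at this position is highly sensitive to the group it carries. Compound 1 keeps its low value only with tert-butyl in place, and methoxy does not stand in for it on the shared core. Nothing among the data shown accounts for the size of this step. The compounds shown leave open whether an isopropyl group, a chlorine atom or trifluoromethyl at this carbon would stay close to compound 1 or fall towards compound 3. They also leave open whether the same change would act alike on the core of compound 2.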